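A few compounds are considered here, and "the series" means these few. Any claim that something is new, unique, unknown or untested is made for them only; others in the source may bear on it.

Compound 1 `O=C(c1ccc(Cl)cc1)N1CCC(NS(=O)(=O)c2cc(S(=O)(=O)c3ccccc3)ccc2C(F)(F)F)CC1`: 300 nM
Compound 2 `CN(C)c1ccc(C(=O)N2CCC(NS(=O)(=O)c3cc(S(=O)(=O)c4ccccc4)ccc3C(F)(F)F)CC2)cc1`: 300 nM

In an assay on isolated protein for displacement of a labelled ligand from secreted frizzled-related protein 1 (Homo sapiens), read by fluorescence polarization, with a stated time of 30 min (on this read-out lower numbers stand for stronger inhibition and higher numbers for weaker inhibition), compound 1 gives 300 nM, and compound 2 gives 300 nM. Among the measured compounds shown here, compound 2 therefore stands level with compound 1, its only measured neighbour: the step of no change at the digits printed from compound 1 to compound 2 (within the scatter) shows that putting dimethylamino in place of chloro on an aromatic carbon left the reading where it was. Compound 3 `CN(C)c1ccc(C(=O)N2CCC(NS(=O)(=O)c3cc(S(=O)(=O)c4ccccc4)ccc3C(F)(F)F)CC2)cn1` has not yet been measured. It differs from compound 2 in one place: 6-(dimethylamino)pyridin-3-yl in place of 4-(dimethylamino)phenyl on a carbonyl carbon. For the measured compounds named here, no measured step alters the ring itself; the one step known, no change at the digits printed from compound 1 to compound 2 (within the scatter), changed only the group carried on that ring and moved nothing beyond the scatter. The change to compound 3 is likewise small, so the expected step of no change at the digits printed from compound 2 to compound 3 (within the scatter) is none beyond the scatter. For compound 3 the estimate in this assay is 300 nM, within a range from 150 nM to 650 nM.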

Compound 3, half-maximal inhibitory concentration: 40 nM
For compound 3 the middle estimate is 7.5-fold (0.88 log units) above the measured one; the whole stated range lies above it.
By their numbers in this assay, from the lowest: compound 3; then compounds 1 and 2 (each within the scatter of the next).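

In this assay, the ring on the carbonyl carbon turns out to matter: 6-(dimethylamino)pyridin-3-yl in place of 4-(dimethylamino)phenyl gives a 7.5-fold lower number from compound 2 to compound 3 (0.88 log units; beyond the scatter) even though the dimethylamino group stays, whereas the earlier change of the group on the ring moved nothing beyond the scatter. Set against the 4-chlorophenyl group, the same pyridine ring gives a 7.5-fold lower number from compound 1 to compound 3 (0.88 log units; beyond the scatter) and so stands apart from both phenyl compounds. Nothing available explains why a ring with one nitrogen in place of a carbon reads differently.

Still open, as far as these compounds go, is whether the ring nitrogen acts alone or needs the dimethylamino group alongside it. A chloro group or a morpholine in place of dimethylamino on the pyridine ring would tell these two readings apart.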